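Amide aryl variation on the shared core: compound 3

The source may hold more compounds than are shown below. What is called first, only, known or untested is meant among the compounds shown, and "the series" means these compounds.

The series shares one core carrying an amide whose nitrogen bears a substituted phenyl group. Compound 1 `COc1cccc(NC(=O)COc2ccc3cc(/C=C4/SC(=O)NC4=O)ccc3c2)c1` has 3-methoxyphenyl there; in an assay on isolated protein for inhibition of histone deacetylase 4 (Homo sapiens), with a stated time of 1 h (on this read-out higher numbers stand for weaker inhibition and lower numbers for stronger inhibition), compound 1 gives 1600 nM. Compound 2 `O=C(COc1ccc2cc(/C=C3/SC(=O)NC3=O)ccc2c1)Nc1ccc(Cl)c(Cl)c1` has 3,4-dichlorophenyl; in this assay compound 2 gives 5500 nM. For the measured compounds named here, the single measured step, a 3.4-fold higher number from compound 1 to compound 2 (0.54 log units; beyond the scatter), is the only guide to what the amide-type nitrogen tolerates. Compound 2 thus stands at the higher of the two numbers, with compound 1 the nearest and lower.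

Compound 3 `O=C(COc1ccc2cc(/C=C3/SC(=O)NC3=O)ccc2c1)Nc1c(F)cc(F)cc1Br` keeps everything of compound 2 except this change: 2-bromo-4,6-difluorophenyl in place of 3,4-dichlorophenyl on an amide-type nitrogen. Going by the values given here, no measured step covers an aryl group substituted in this pattern; the step from compound 1 to compound 2 bears on it only in showing that a change of the substituent set on this phenyl moved the number modestly. The expectation for this assay is therefore a step of no more than modest size in either direction, most likely none beyond the scatter. Compound 3 is estimated at 5000 nM, with a range of 1500 nM to 16000 nM. The step this estimate implies is a 1.1-fold lower number from compound 2 to compound 3 (0.04 log units; within the scatter).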

Compound 3, half-maximal inhibitory concentration: 1100 nM
For compound 3 the middle estimate is 4.5-fold (0.66 log units) above the measured one; the measured number lies below the stated range.
By their numbers in this assay, from the lowest: compounds 3 and 1 (each within the scatter of the next); then compound 2.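

Notes on the aryl group on the amide-type nitrogen: in this assay this position responds in both directions, and a 5.0-fold lower number from compound 2 to compound 3 (0.70 log units; beyond the scatter) shows that the loss seen with 3,4-dichlorophenyl can be recovered without a methoxy group on the ring. Halogen substitution alone therefore does not go with the higher number: compound 2 and compound 3 both carry only halogens on the phenyl, yet they differ beyond the scatter, while a 1.5-fold lower number from compound 1 to compound 3 (0.16 log units; within the scatter) leaves 2-bromo-4,6-difluorophenyl and 3-methoxyphenyl indistinguishable on this read-out. No supporting data are available to explain the difference between these aryl groups.

Compound 2 and compound 3 differ in the identity and the placement of their halogens at once, so the contributions of bromine, fluorine and chlorine cannot be separated from the pattern in which they stand. Also open, on these data alone, is how this read-out responds to an unsubstituted phenyl, to a phenyl carrying an amine or a carboxylic acid, or to a longer chain in place of the aryl group on the amide-type nitrogen.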